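A few compounds are considered here, and "the series" means these few. Any claim that something is new, unique, unknown or untested is made for them only; others in the source may bear on it.

Compound 2 `Cc1cccc2c1cnn2-c1cncc(C(C)(C)O)c1` gives 7.77 nM in an assay on cells for inhibition of cytochrome P450 11B2, mitochondrial (Homo sapiens), read by HTRF, with stated times of 1 h and 3 h (a higher number here means a weaker inhibitor, a lower number a stronger inhibitor), the highest of the two numbers, though compound 1 `CC(C)(O)c1cncc(-n2ncc3c(F)cccc32)c1` stands nearest with 7.58 nM, and the step of a 1.0-fold higher number from compound 1 to compound 2 (0.01 log units; within the scatter) lies within the scatter. Compound 3 `COC(=O)c1cccc2c1cnn2-c1cncc(C(C)(C)O)c1` is reached from compound 2 by methoxycarbonyl in place of methyl on an aromatic carbon. Among the compounds with values here, only that single step from compound 1 to compound 2 concerns the same position, and it did not move the number beyond the scatter, so the data give little guidance. Compound 3 is therefore expected to show a step of a 1.9-fold higher number from compound 2 to compound 3 (0.29 log units; within the scatter), with an estimated 15 nM ranging from 5 nM to 60 nM.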

Compound 3, half-maximal inhibitory concentration: 22 nM
For compound 3 the middle estimate is 1.5-fold (0.17 log units) below the measured one; measured number inside the range.
By their numbers in this assay, from the lowest: compounds 1 and 2 (each within the scatter of the next); then compound 3.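

Methoxycarbonyl is the first group at this position to move the number in this assay beyond the scatter, with a 2.8-fold higher number from compound 2 to compound 3 (0.45 log units; beyond the scatter) and a 2.9-fold higher number from compound 1 to compound 3 (0.46 log units; beyond the scatter). Fluoro and methyl could not be told apart here, so the position does respond to what it carries, though only modestly for this change. Nothing available accounts for the rise. The compounds shown leave open whether an amide, a carboxylic acid or a nitrile at this position would give a number like that of compound 3 or like those of compound 1 and compound 2.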